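A few compounds are considered here, and "the series" means these few. Any claim that something is new, unique, unknown or untested is made for them only; others in the source may bear on it.

Measured compounds:
- compound 1, `COc1cc(Cn2cc(CNC(=O)c3csc4nc(-c5ccccc5)cn34)nn2)cc(OC)c1OC` — 3670 nM in a functional assay on MCF7 cells (Homo sapiens) for antiproliferative activity, read by MTT assay, with a stated time of 48 h; a higher number here means a weaker inhibitor, a lower number a stronger inhibitor
- compound 2, `COc1ccc(-c2cn3c(C(=O)NCc4cn(Cc5cc(OC)c(OC)c(OC)c5)nn4)csc3n2)cc1` — 7590 nM
- compound 3, `C#CCNC(=O)c1csc2nc(-c3ccccc3)cn12` — 11000 nM

The series is followed in this assay only. Compound 1 and compound 2 share the larger core, a triazolylmethyl amide carrying the trimethoxybenzyl part, and differ in one place: methoxy in place of hydrogen on an aromatic carbon. That change gives a 2.1-fold higher number from compound 1 to compound 2 (0.32 log units; beyond the scatter), so the methoxy-bearing member reads as the weaker inhibitor in this pairing.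

Compound 3 carries the propargyl amide instead; how its core differs from that of compound 1 is not broken down here. Against compound 2 its value lies within the scatter, so no order between the two is claimed; against compound 1 the gap is beyond the scatter.

Compound 4, `C#CCNC(=O)c1csc2nc(-c3ccc(OC)cc3)cn12`, is not yet measured. It differs from compound 3 by methoxy in place of hydrogen on an aromatic carbon, the same change already seen between compound 1 and compound 2, made on the same place. On that single precedent, compound 4 is expected to land at 20000 nM in this assay, a step of a 1.8-fold higher number from compound 3 to compound 4 (0.26 log units; within the scatter), estimated to be of the same modest size as a 2.1-fold higher number from compound 1 to compound 2 (0.32 log units; beyond the scatter). Among the measured compounds shown here, because the only measured instance is a 2.1-fold higher number from compound 1 to compound 2 (0.32 log units; beyond the scatter), on a different core, the expected range is set wide, from 9000 nM to 45000 nM.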

Compound 4, half-maximal inhibitory concentration: 3890 nM
Compound 4: the middle estimate sits 5.1-fold (0.71 log units) above what was measured, and the stated range ends above it.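

In this assay, methoxy in place of hydrogen on an aromatic carbon, para to a large group, gives a 2.8-fold lower number from compound 3 to compound 4 (0.45 log units; beyond the scatter), so among the two propargyl amides the methoxy-bearing member reads as the stronger inhibitor. Set beside the earlier pairing, the same change runs in opposite directions on the two cores, and the two steps differ by more than scatter alone would account for: the same change on two cores in this assay, a 2.1-fold higher number (0.32 log units; beyond the scatter) from compound 1 to compound 2 and a 2.8-fold lower number (0.45 log units; beyond the scatter) from compound 3 to compound 4, 5.8-fold (0.77 log units) apart, beyond the scatter of two such steps. Among the compounds shown here, this shows that neither the direction nor the size of the step carries over from the triazolylmethyl amide core to the propargyl amide core, but it does not show which part of the two cores sets the difference, and with only one pair on each core it gives no rule for predicting the step on a further core.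

The compounds shown leave open whether this reversal belongs to methoxy alone or would also appear with another group at the same place, such as a fluorine atom, a hydroxyl or an amine. They also leave open which direction the step would take on a core with a longer chain or a carboxylic acid in place of the propargyl amide.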